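The source may report more compounds than this note shows. Statements on the series, on what has been measured and on what is new or still open speak of the compounds shown alone.

Compound 1 `Nc1nc(SCc2ccccc2)c2ncn([C@@H]3C[C@H](O)[C@@H](CO)O3)c2n1` carries a benzylsulfanyl group on the shared core, and in a functional assay on L1210 cells (Mus musculus) for inhibition, read by thymidine incorporation (on this read-out higher numbers stand for an effect only at larger amounts of compound and lower numbers for an effect already at smaller amounts), the record for compound 1 reads "not determined" (no result reported). Compound 2 `Nc1nc(SCc2ccccc2)c2ncn([C@H]3C[C@H](O)[C@@H](CO)O3)c2n1` is its partner, since (the fact that compounds 1 and 2 differ only in the configuration as drawn), and for compound 2 the entry in this assay likewise reads "not determined" (no result reported). Among the compounds with values here, the only number belongs to compound 3 `C=CCSc1nc(N)nc2c1ncn2[C@H]1C[C@H](O)[C@@H](CO)O1`, which in this assay gives 5.5 uM. Compound 4 `Cc1cccc(CSc2nc(N)nc3c2ncn3[C@@H]2C[C@H](O)[C@@H](CO)O2)n1` is reached from compound 1 by the change (6-methylpyridin-2-yl in place of phenyl on a saturated chain carbon bound to a sulfur). Within the data shown here, with no measured step to lean on, the shift in this assay is expected to be modest, most likely within the scatter or slightly weaker. Compound 4 is therefore estimated at 10 uM, in a range from 2 uM to 50 uM.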

Compound 4, concentration for half-maximal effect: 79 uM
Compound 4: the middle estimate sits 7.9-fold (0.90 log units) below what was measured; the whole stated range lies below it.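

In this assay compound 1 has no single number, so no new step can be read from compound 4. The compounds shown leave open how far 6-methylpyridin-2-yl in place of phenyl shifts this read-out. Nothing at hand bears on the result for compound 4.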